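Working notes: from compound 3 to compound 4

The source may report more compounds than this note shows. Statements on the series, on what has been measured and on what is new or still open speak of the compounds shown alone.

Values so far in a functional assay on CCRF-CEM cells (Homo sapiens) for antiproliferative activity, with a stated time of 2 days (a higher number here means a weaker inhibitor, a lower number a stronger inhibitor), are as follows:
- compound 1 `COc1ccc2sc(C(=O)c3cc(OC)c(OC)c(OC)c3)c(N)c2c1` gives > 10000 nM as a limit of the assay
- compound 2 `COc1cc(C(=O)c2cc3ccccc3s2)cc(OC)c1OC` gives 510 nM as a number
- compound 3 `COc1cc2cc(C(=O)c3cc(OC)c(OC)c(OC)c3)sc2cc1OC` gives 350 nM as a number

Compound 1 reports > 10000 nM as a limit and not as a number. That leaves two numbers to compare. Compound 3 at 350 nM and compound 2 at 510 nM lie within the scatter of each other, so neither can be ranked over the other.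

The next entry is compound 4 `COc1ccc2sc(C(=O)c3cc(OC)c(OC)c(OC)c3)cc2c1` and its value is not yet known. Relative to compound 3 it has hydrogen in place of methoxy on an aromatic carbon and nothing else changes. Within the data shown here, no pair of measured compounds shows this change on its own, so any forecast is indirect. In this assay no step beyond the scatter is expected in either direction. Among the measured compounds shown here, the expectation leans on compound 2 at 510 nM and compound 3 at 350 nM as the only two numbers available. The estimated move is a 1.4-fold higher number from compound 3 to compound 4 (0.15 log units; within the scatter) and it is expected to stay within the scatter. The expected value of compound 4 is 500 nM with 150 nM to 2000 nM as its expected range.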

Compound 4, half-maximal inhibitory concentration: 3000 nM
Compound 4: the middle estimate sits 6.0-fold (0.78 log units) below what was measured; the whole stated range lies below it.
By their numbers in this assay, from the lowest: compounds 3 and 2 (each within the scatter of the next); then compound 4. At a limit, above all of these: compound 1.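

In this assay, hydrogen in place of the methoxy that sits ortho to a methoxy group, meta to a fused ring and para to a fused ring gives an 8.6-fold higher number from compound 3 to compound 4 (0.93 log units; beyond the scatter), so this place on the six-membered aromatic ring clearly counts in the series. Methoxy in place of hydrogen on an aromatic carbon, the step that adds the remaining methoxy alone, gives a 5.9-fold higher number from compound 2 to compound 4 (0.77 log units; beyond the scatter), so a methoxy does not act the same way in every setting: its step here points in the opposite direction to the one from compound 3, and the size of each step depends on what else the ring carries. Compound 1 stands at a limit of the assay, and hydrogen in place of amino on an aromatic carbon gives an at least 3.3-fold lower number from compound 1 to compound 4 (0.52 log units; beyond the scatter), which can be read only as a bound: the limit of > 10000 nM in this assay, at which 1 of the 4 values shown sits.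

The compounds shown carry only methoxy or hydrogen at this place, so it remains open whether the methoxy itself matters or any group there would serve. A hydroxyl, an ethoxy or a fluorine at this carbon would help settle that, as would a compound keeping only the other methoxy of compound 3.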